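A few compounds are considered here, and "the series" means these few. Any claim that something is new, unique, unknown or untested is made for them only; others in the source may bear on it.

Compound 1 `O=c1cc(-c2ccccc2)oc2cc(OCCCCNc3nc4ccccc4s3)cc(O)c12` gives 4.75 ug/mL in a functional assay on HeLa cells (Homo sapiens) for cytotoxicity, read by sulforhodamine B assay, with a stated time of 48 h (on this read-out lower numbers stand for stronger inhibition and higher numbers for weaker inhibition), and stands lowest of the two numbers measured, though its nearest neighbour, compound 2 `O=c1cc(-c2ccccc2)oc2cc(OCCCCNc3nc4ccc(Cl)cc4s3)cc(O)c12`, gives 5.95 ug/mL, within the scatter. Within the data shown here, the only measured step, a 1.3-fold higher number from compound 1 to compound 2 (0.10 log units; within the scatter), concerns chloro in place of hydrogen on an aromatic carbon and so does not touch the change that leads to compound 3 `O=c1cc(-c2ccccc2)oc2cc(OCCCCNNc3nc4ccccc4s3)cc(O)c12`: (1,3-benzothiazol-2-yl)amino in place of 1,3-benzothiazol-2-yl on an amine nitrogen. Among the measured compounds shown here, no measured pair shows what this change does, so compound 3 is expected to show no step beyond the scatter, with a 1.1-fold higher number from compound 1 to compound 3 (0.02 log units; within the scatter). For compound 3 the estimated value in this assay is 5 ug/mL, expected to fall between 2.4 ug/mL and 10.5 ug/mL.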

Compound 3, half-maximal inhibitory concentration in the HeLa assay: 4.64 ug/mL
The estimate for compound 3 lay 1.1-fold (0.03 log units) above the measured number; measured number inside the range.
By their numbers in the HeLa assay, from the lowest: compounds 3, 1 and 2 (each within the scatter of the next).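

In the HeLa assay (1,3-benzothiazol-2-yl)amino in place of 1,3-benzothiazol-2-yl on the amine nitrogen gives a 1.0-fold lower number from compound 1 to compound 3 (0.01 log units; within the scatter) and so no change that can be told from the scatter. In a physicochemical assay, read by spectrophotometry, with a stated time of 10 min (on this read-out lower numbers stand for stronger inhibition and higher numbers for weaker inhibition), compound 1 gives 8.57 ug/mL and compound 3 gives 8.73 ug/mL and this agrees, with a 1.0-fold higher number from compound 1 to compound 3 (0.01 log units; within the scatter) as its step. In the HeLa assay the step of a 1.3-fold lower number from compound 2 to compound 3 (0.11 log units; within the scatter) also stays within the scatter, so this position has tolerated the larger group in both assays so far. No evidence at hand explains this. Still open, on these data alone, is whether an amide or a carboxylic acid at this amine nitrogen, or a longer chain, would move either number beyond the scatter.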